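The compounds below may be only part of what the source reports. "The series", "measured", "known", "first", "only" and "open" are said of these compounds alone.

Compound 1 `C/C(=N\NC(=O)Nc1nc2ccc(CN(C)C)cc2s1)c1ccccn1` and compound 2 `CCN(CC)Cc1ccc2nc(NC(=O)N/N=C(\C)c3ccccn3)sc2c1` share one core, while compound 3 `CN(C)Cc1ccc(NC(=O)NN=C(c2ccccn2)c2ccccn2)cc1` and compound 4 `CCN(CC)Cc1ccc(NC(=O)NN=C(c2ccccn2)c2ccccn2)cc1` share another; the difference between the two cores is not broken down here. In a functional assay on U-937 cells (Homo sapiens) for antiproliferative activity, read by CCK-8 assay, with a stated time of 24 h (a higher number here means a weaker inhibitor, a lower number a stronger inhibitor), compound 1 gives 20100 nM. In this assay compound 2 gives 15600 nM. Compound 2 differs from compound 1 by diethylamino in place of dimethylamino on a saturated chain carbon bound to an aromatic carbon, and this change produced a 1.3-fold lower number from compound 1 to compound 2 (0.11 log units; within the scatter). For compound 3 in this assay only a limit is known, > 40000 nM, which is the limit of > 40000 nM in this assay, at which 1 of the 3 values shown sits. Compound 4 differs from compound 3 by the same change, (diethylamino in place of dimethylamino on a saturated chain carbon bound to an aromatic carbon). Compound 4 is expected to move only a little from compound 3, a step that the limit leaves unreadable from compound 3 to compound 4, an expectation resting on the measured step of a 1.3-fold lower number from compound 1 to compound 2 (0.11 log units; within the scatter). Compound 4 is therefore estimated to give about 45000 nM in this assay, most likely somewhere between 20000 nM and 100000 nM, and it may well come back as a limit rather than a number.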

Compound 4, half-maximal inhibitory concentration: > 40000 nM
Compound 4 gave a limit, no number; the forecaster's own chance of this, stated with the estimate: 70%; the middle value lies beyond the limit too.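

Compound 3 and compound 4 both give only a limit, not a number, in this assay, so no step can be read between them. The compounds shown leave open how strongly either compound actually acts on these cells, and whether diethylamino in place of dimethylamino makes any difference on their shared core.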